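Homologation of the primary amine side chain in compound 1

The compounds below may be only part of what the source reports. "The series", "measured", "known", "first", "only" and "open" are said of these compounds alone.

Measured compounds:
compound 1, `COc1cccc(-c2c(C)n(Cc3c(F)cccc3F)c(=O)n(C[C@@H](N)C(C)C)c2=O)c1F`, 973 nM in an assay on HEK293 cells for binding affinity to Gonadotropin-releasing hormone receptor (Homo sapiens), read by radioligand binding; a lower number here means a stronger inhibitor, a higher number a weaker inhibitor
compound 2, `COc1cccc(-c2c(C)n(Cc3c(F)cccc3F)c(=O)n(C[C@H](NC(C)C)C3CCCC3)c2=O)c1F`, 12 nM
compound 3, `COc1cccc(-c2c(C)n(Cc3c(F)cccc3F)c(=O)n(C[C@@H](C3CCCCC3)N(C)C)c2=O)c1F`, 4.1 nM

Compound 1 gives the highest number of the three; its nearest neighbour is compound 2, with an 81-fold lower number from compound 1 to compound 2 (1.91 log units; beyond the scatter), and compound 3 lies furthest, with a 240-fold lower number from compound 1 to compound 3 (2.38 log units; beyond the scatter). Between them, a 2.9-fold lower number from compound 2 to compound 3 (0.47 log units; beyond the scatter).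

Compound 4, `COc1cccc(-c2c(C)n(Cc3c(F)cccc3F)c(=O)n(C[C@H](N)CC(C)C)c2=O)c1F`, differs from compound 1 by 1-amino-3-methylbutyl in place of 1-amino-2-methylpropyl on a saturated chain carbon bound to an aromatic nitrogen. The measured steps each replaced the primary amine and added a ring at once, so none bears directly on this change; they show only that the chain bound to the aromatic nitrogen tolerates larger groups. A step of no more than modest size is expected here, a 1.6-fold lower number from compound 1 to compound 4 (0.21 log units; within the scatter). Compound 4 is expected to give 600 nM, within 200 nM to 2000 nM.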

Compound 4, inhibition constant: 6.4 nM
Estimate against measurement, compound 4: 94-fold (1.97 log units) above, outside the stated range (below it).
By their numbers in this assay, from the lowest: compounds 3, 4 and 2 (each within the scatter of the next, the first and the last beyond it); then compound 1.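

In this assay, a 150-fold lower number from compound 1 to compound 4 (2.18 log units; beyond the scatter), so a primary amine on a saturated chain carbon bound to an aromatic nitrogen does not by itself keep the number high. Neither the ring nor the substituted amine of the other two compounds is needed to reach their range: a 1.9-fold lower number from compound 2 to compound 4 (0.27 log units; within the scatter), and a 1.6-fold higher number from compound 3 to compound 4 (0.19 log units; within the scatter). The available evidence offers no account of the size of this step.

Compound 1 alone is drawn with the opposite spatial arrangement at its stereocentre, so the chain change and the stereocentre remain inseparable in this step. On these data alone, how a longer chain such as 1-amino-4-methylpentyl, or a dimethylamino group on the 1-amino-3-methylbutyl chain, would read remains open.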